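Methylating the aryl hydroxyl of compound 2

This account rests on a few compounds, and the source may have more. Where it says the series, first, only, none or still open, it means among the compounds named here.

Within a functional assay on HT-29 cells (Homo sapiens) for cytotoxicity, read by XTT assay, with a stated time of 72 h (a lower number here means a stronger inhibitor, a higher number a weaker inhibitor), two compounds give a number and one only a limit. Compound 2 `C=C1CC[C@H]2C(C)(C)CCC[C@]2(C)[C@H]1CC/C(C)=C/COc1c(-c2ccc(O)cc2)oc2cc(O)cc(O)c2c1=O` gives 30000 nM, and compound 1 `CCCCCCCCCCCCCCCCCCc1c(O)cc(O)c(C(C)=O)c1O` gives 28000 nM; the gap between them lies within the scatter, so neither is ranked above the other. Compound 3 `CCCCCCCC/C=C\CCCCCCCCc1c(O)cc(O)c(C(C)=O)c1O` sits at the limit (the limit of > 100000 nM in this assay, at which 1 of the 3 values shown sits), giving > 100000 nM. Among the compounds with values here, the single measured step, an at least 3.5-fold higher number from compound 1 to compound 3 (0.55 log units; beyond the scatter), concerns the saturated chain of the core of compound 1 and has no bearing on an aryl oxygen. Compound 4 `C=C1CC[C@H]2C(C)(C)CCC[C@]2(C)[C@H]1CC/C(C)=C/COc1c(-c2ccc(OC)cc2)oc2cc(O)cc(O)c2c1=O` differs from compound 2 by methyl in place of hydrogen on an oxygen on an aromatic ring. Within the data shown here, no measured step speaks to this change, so no shift beyond the scatter is expected. Compound 4 is therefore estimated at 30000 nM, with a range of 10000 nM to 90000 nM. The expected step is no change at the digits printed from compound 2 to compound 4 (within the scatter).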

Compound 4, half-maximal inhibitory concentration: 32000 nM
For compound 4 the middle estimate is 1.1-fold (0.03 log units) below the measured one, and the stated range covers the measured number.
By their numbers in this assay, from the lowest: compounds 1, 2 and 4 (each within the scatter of the next). At a limit, above all of these: compound 3.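

Hydroxy to methoxy on this aromatic oxygen reads as a 1.1-fold higher number from compound 2 to compound 4 (0.03 log units; within the scatter) in this assay, so the hydrogen on this oxygen can give way to methyl without a shift beyond the scatter. Within the data shown here, this is the first measured step at an aryl oxygen, as the earlier step concerned only the saturated chain of the core of compound 1. No measurement shown offers a reason for this outcome.

From the compounds shown here alone, whether an ethyl group, a longer chain, or a chain ending in an amine or a carboxylic acid on this oxygen would hold the same level remains open. The hydroxyl groups on the shared core also remain untested by any step shown.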